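Sulfonyl cinnamamides: methyl added to the bromo analogue

The source may report more compounds than this note shows. Statements on the series, on what has been measured and on what is new or still open speak of the compounds shown alone.

Two members of this series have been measured. Compound 1 `Cc1ccc(S(=O)(=O)NC(=O)/C=C/c2ccccc2)cc1` gives 13.8 ug/mL in a functional assay on B16-F10 cells (Mus musculus) for antiproliferative activity, read by ELISA and MTT assay, with a stated time of 48 h; a lower number here means a stronger inhibitor, a higher number a weaker inhibitor. Compound 2 `O=C(/C=C/c1ccc(Br)cc1)NS(=O)(=O)c1ccccc1` gives 3.9 ug/mL in this assay, the lowest of the two numbers; compound 1 is its nearest neighbour, with a higher number beyond the usual scatter. Going by the values given here, the two differ in two places at once, so no single step between them is available, and their values show only that compound 2 is the stronger of the pair.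

Compound 3 `Cc1ccc(S(=O)(=O)NC(=O)/C=C/c2ccc(Br)cc2)cc1` is not yet measured. Its difference from compound 2 is methyl in place of hydrogen on an aromatic carbon, placed on the aromatic carbon para to a large group. Among the compounds with values here, no measured step isolates this change, so nothing in the data points to a direction. The step of a 1.2-fold higher number from compound 2 to compound 3 (0.06 log units; within the scatter) is therefore expected to stay within the scatter. Compound 3 is estimated at 4.5 ug/mL, with a range from 2 ug/mL to 10 ug/mL.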

Compound 3, half-maximal inhibitory concentration: 12.1 ug/mL
Compound 3: middle estimate off by 2.7-fold (0.43 log units), on the low side; measured number outside the range, above it.
By their numbers in this assay, from the lowest: compound 2; then compounds 3 and 1 (each within the scatter of the next).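

In this assay, going by these compounds alone, methyl in place of hydrogen on the aromatic carbon para to a large group gives a 3.1-fold higher number from compound 2 to compound 3 (0.49 log units; beyond the scatter) and so is not a silent change at this position, which no earlier pair could show. With the methyl present, bromo in place of hydrogen gives a 1.1-fold lower number from compound 1 to compound 3 (0.06 log units; within the scatter) and does not separate the two compounds, leaving compound 2 alone apart from the other two. No measurement at hand accounts for the methyl step.

Whether bromo in place of hydrogen reads the same without the methyl remains open, as the shared core carrying neither group is not among the compounds shown. Also open, as far as these compounds go, is how an ethyl, a methoxy, an amine or a carboxylic acid would read on this same aromatic carbon, and thus whether the step belongs to methyl alone.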